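Chain extension on the octyl tail of compound 3

A few compounds are considered here, and "the series" means these few. Any claim that something is new, unique, unknown or untested is made for them only; others in the source may bear on it.

Three members of the series carry the same core and differ only on the aromatic ring of the phenylpiperazine. Compound 1 `CCCCCCCCn1cc(/C=C/C(=O)c2ccc(NC(=O)CN3CCN(c4ccccc4)CC3)cc2)nn1` gives 52400 nM in a functional assay on A549 cells (Homo sapiens) for inhibition, read by MTT assay; on this read-out lower numbers stand for stronger inhibition and higher numbers for weaker inhibition. Compound 2 `CCCCCCCCn1cc(/C=C/C(=O)c2ccc(NC(=O)CN3CCN(c4ccccc4F)CC3)cc2)nn1` gives 47100 nM; the step is a 1.1-fold lower number from compound 1 to compound 2 (0.05 log units; within the scatter). Compound 3 `CCCCCCCCn1cc(/C=C/C(=O)c2ccc(NC(=O)CN3CCN(c4ccccc4OC)CC3)cc2)nn1` gives 34000 nM; the steps are a 1.5-fold lower number from compound 1 to compound 3 (0.19 log units; within the scatter) and a 1.4-fold lower number from compound 2 to compound 3 (0.14 log units; within the scatter). All three numbers therefore sit together within the scatter, and no ring substituent separates itself from the others.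

Compound 4 `CCCCCCCCCCn1cc(/C=C/C(=O)c2ccc(NC(=O)CN3CCN(c4ccccc4OC)CC3)cc2)nn1` is not yet measured. It differs from compound 3 in one place: ethyl in place of hydrogen on a saturated chain carbon, eight bonds along the chain from an aromatic nitrogen. None of the three measured steps touches the alkyl chain; all of them change the aromatic ring, and each stayed within the scatter. Within the data shown here, nothing in the measured set speaks to lengthening the chain, so the only guide is that every change made so far left the read-out essentially unmoved.

The step from compound 3 to compound 4 is therefore expected to be no change at the digits printed from compound 3 to compound 4 (within the scatter), with no direction beyond the scatter. Compound 4 is estimated at 34000 nM, with a range from 14000 nM to 85000 nM, the width reflecting that the chain has not been varied before.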

Compound 4, half-maximal inhibitory concentration: 62500 nM
Compound 4: middle estimate off by 1.8-fold (0.26 log units), on the low side; measured number inside the range.
By their numbers in this assay, from the lowest: compounds 3, 2, 1 and 4 (each within the scatter of the next).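

Unlike the three earlier steps, all on the aromatic ring of the phenylpiperazine, this one bears on the alkyl chain: in this assay, ethyl in place of hydrogen on a saturated chain carbon, eight bonds along the chain from an aromatic nitrogen, gives a 1.8-fold higher number from compound 3 to compound 4 (0.26 log units; within the scatter). Among these compounds, this change therefore does not separate compound 4 from compound 3 on this read-out, and the chain joins the aromatic ring as a place where the single change seen so far stays within the scatter. Nothing available explains this result or links it to any property of the chain.

Still open, on these data alone, is whether a shorter chain, a much longer chain, or a chain ending in an amine or a carboxylic acid would give a step beyond the scatter, since one step at one position does not define how the chain behaves across its length. Also open, as far as these compounds go, is whether the same ethyl extension would give a similar step with the unsubstituted or fluoro ring of compound 1 and compound 2, so the chain and ring changes cannot yet be treated as independent.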